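The source may hold more compounds than are shown below. What is called first, only, known or untested is meant among the compounds shown, and "the series" means these compounds.

Measured compounds:
- compound 1 `O=C(Nc1cccc(-n2cc(-c3ccncc3)c(-c3cc(O)cc(Cl)c3)n2)c1)Nc1ccc(Cl)c(C(F)(F)F)c1`: 104%
- compound 2 `O=C(Nc1cccc(-n2cc(-c3ccncc3)c(-c3cc(O)cc(Cl)c3)n2)c1)Nc1ccc(Cl)c(Cl)c1`: 56%
- compound 3 `COc1cc(Cl)cc(-c2nn(-c3cccc(NC(=O)Nc4cc(C(F)(F)F)cc(C(F)(F)F)c4)c3)cc2-c2ccncc2)c1`: 40%

All three were tested in a functional assay on SK-MEL-2 cells (Homo sapiens) for inhibition, read by sulforhodamine B assay, with a stated time of 48 h, tested at 1 uM; a lower number here means a stronger effect, a higher number a weaker effect of the compound at the concentration tested. Compound 3 gives the lowest of the three numbers, and so the strongest effect: compound 2 sits above it by a gap beyond the scatter, and compound 1 sits far above both. Going by the values given here, the only measured step between two compounds that differ in one place is a number 48 percentage points lower from compound 1 to compound 2 (beyond the scatter), a large drop in the number when a trifluoromethyl group on the urea-bearing ring gives way to chloro.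

Compound 4 `COc1cc(Cl)cc(-c2nn(-c3cccc(NC(=O)Nc4cccc(C(F)(F)F)c4)c3)cc2-c2ccncc2)c1` differs from compound 3 in one place: hydrogen in place of trifluoromethyl on an aromatic carbon. Among the compounds with values here, the one measured step concerns the same kind of group on the same part of the molecule, yet there the trifluoromethyl was swapped for chloro rather than taken away, so it bears on this change only loosely. With one of two trifluoromethyl groups gone, the effect is expected to weaken somewhat, giving a step of a number 22 percentage points higher from compound 3 to compound 4 (beyond the scatter) in this assay, though a change within the scatter cannot be ruled out. For compound 4 the expected value in this assay is 62%, within a range from 30% to 95%.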

Compound 4, a percentage reported as activity, at one concentration (the size of the read-out at that concentration, not a potency): 85%
Beside the measured number, compound 4's estimate is 23 percentage points below it, within the range that was stated.
By their numbers in this assay, from the lowest: compound 3; then compound 2; then compound 4; then compound 1.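

In this assay, going by these compounds alone, taking one trifluoromethyl group off the ring and leaving hydrogen in its place gives a number 45 percentage points higher from compound 3 to compound 4 (beyond the scatter), so between these two compounds the second trifluoromethyl group goes with a much stronger effect, a finding that no earlier pair could give, since none lost this group without a replacement. The earlier step, a number 48 percentage points lower from compound 1 to compound 2 (beyond the scatter), runs the other way, with the number falling when chloro replaces a trifluoromethyl group on the same ring, so losing a trifluoromethyl group has no single outcome across these two pairs, and what enters in its place and the rest of the substitution may both count. Nothing at hand gives a measured reason for either step.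

The compounds shown leave open how other groups would behave at this place on the ring, for example a methyl group, an amine or a nitrile, each of which would show whether hydrogen is unusually poor there. They also leave open whether the first step and the new one would keep their sizes on a shared background, as the two pairs differ elsewhere in the molecule.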